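The compounds below may be only part of what the source reports. "The series", "measured", "known", "first", "only" and "open" are said of these compounds alone.

The compounds measured so far, with their values in a functional assay on HCT-116 cells (Homo sapiens) for antiproliferative activity, with a stated time of 72 h; a higher number here means a weaker inhibitor, a lower number a stronger inhibitor:

compound 1, `Cc1[nH]c2ccccc2c1C1=CCC(NCc2ccc(OCC(=O)NO)cc2F)CC1`, gives 99 nM;
compound 3, `Cc1[nH]c2cccc(F)c2c1C1=CCC(NCc2ccc(OCC(=O)NO)cc2F)CC1`, gives 254 nM;
compound 2, `O=C(COc1ccc(C(=O)N2CC=C(c3c[nH]c4cccc(F)c34)CC2)cc1)NO`, gives 1410 nM.

Compound 1 stands at the lowest number of the three. Its nearest neighbour is compound 3, reached by a 2.6-fold higher number from compound 1 to compound 3 (0.41 log units; beyond the scatter), a change that amounts to fluoro in place of hydrogen on an aromatic carbon of the fused ring system. Compound 2 lies furthest away, but it differs from compound 1 in several places at once, so its gap says little about any single change.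

Compound 4, `O=C(COc1ccc(CNC2CC=C(c3c[nH]c4ccccc34)CC2)c(F)c1)NO`, differs from compound 1 by hydrogen in place of methyl on an aromatic carbon: the group 2-methyl-1H-indol-3-yl becomes 1H-indol-3-yl. Going by the values given here, no measured pair isolates the loss of this methyl, so the only guide is the single step on the same fused ring system, from compound 1 to compound 3, which was modest. A change of similar scale is therefore expected, more likely towards a higher number than a lower one, though a result within the scatter would not be surprising. For compound 4 the estimate is 200 nM, with a range from 70 nM to 600 nM, meaning an expected step of a 2.0-fold higher number from compound 1 to compound 4 (0.31 log units; beyond the scatter).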

Compound 4, half-maximal inhibitory concentration: 436 nM
Compound 4: the middle estimate sits 2.2-fold (0.34 log units) below what was measured, within the range that was stated.
By their numbers in this assay, from the lowest: compound 1; then compounds 3 and 4 (each within the scatter of the next); then compound 2.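

In this assay, taking the methyl off the five-membered aromatic ring gives a 4.4-fold higher number from compound 1 to compound 4 (0.64 log units; beyond the scatter), so this position does not tolerate the change silently: the single carbon of the methyl is enough to move the number beyond the scatter. Going by these compounds alone, this is the first measured step at this position, and it shows that the methyl group belongs to the better-performing form of the series rather than being a neutral substituent. Together with a 2.6-fold higher number from compound 1 to compound 3 (0.41 log units; beyond the scatter), it means that both single changes shown on the fused system of two rings give a higher number than compound 1, with no step among those shown going the other way, and nothing available explains why the loss of the methyl has this effect.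

The compounds shown leave open whether the methyl itself is the best group at this position, or whether an ethyl, a chloro or a methoxy group there would give a lower number or a higher one. They also leave open whether the step from methyl to hydrogen would be of similar size in a compound that carries the fluoro on the fused ring system.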